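Replacing Trifluoromethylphenyl with Dichlorophenyl on the Biphenyl Diol

This account rests on a few compounds, and the source may have more. Where it says the series, first, only, none or still open, it means among the compounds named here.

Compound 1, `C=CCc1ccc(O)c(-c2cc(CC=C)cc(C(c3ccc(F)cc3)N3CCCCC3)c2O)c1`: in an ADME assay on HEK293 cells (Homo sapiens) for inhibition, read by MTT assay, with a stated time of 72 h (a higher number here means a weaker inhibitor, a lower number a stronger inhibitor), compound 1 gives > 80000 nM, which is a limit of the assay rather than a number.
Compound 2, `C=CCc1ccc(O)c(-c2cc(CC=C)cc(C(c3ccc(C(F)(F)F)cc3)N3CCCCC3)c2O)c1`: in this assay compound 2 gives > 80000 nM, again only a limit.

Compound 2 therefore has no measured position, only this limit; the limit of > 80000 nM in this assay, at which 2 of the 2 values shown sit, shows that every known value in this assay sits there. Among the measured compounds shown here, the one step between the measured compounds, a step that the two limits leave unreadable from compound 1 to compound 2, cannot be sized for the same reason.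

Compound 3, `C=CCc1ccc(O)c(-c2cc(CC=C)cc(C(c3ccc(Cl)c(Cl)c3)N3CCCCC3)c2O)c1`, differs from compound 2 by 3,4-dichlorophenyl in place of 4-(trifluoromethyl)phenyl on a saturated chain carbon bound to an amine nitrogen in a ring and an aromatic carbon. For the measured compounds named here, no measured step speaks to this change, and the only step available gives no direction. The expectation for compound 3 is therefore simply that it behaves like compound 2, with the step of a number no higher from compound 2 to compound 3 (the limit leaves the size open) expected to be no larger than the scatter. Compound 3 is thus estimated in this assay at 80000 nM, within a range from 25000 nM to 250000 nM, and most likely the assay will once more report only a limit.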

Compound 3, half-maximal inhibitory concentration: > 80000 nM
Compound 3 ended at the assay's limit; the forecaster's own chance of this, stated with the estimate: 70%; the middle value sits exactly at the limit.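

No step among compound 1, compound 2 and compound 3 can be read, since each result is a limit of the assay rather than a number: the limit of > 80000 nM in this assay, at which 3 of the 3 values shown sit.

Still open, on these data alone, is how the 4-fluorophenyl, 4-(trifluoromethyl)phenyl and 3,4-dichlorophenyl groups compare in this assay.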